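The compounds below may be only part of what the source reports. "The series", "measured", "known", "first", "only" and "open" are said of these compounds alone.

In a functional assay on MCF7 cells (Homo sapiens) for inhibition, read by sulforhodamine B assay (on this read-out lower numbers stand for stronger inhibition and higher numbers for weaker inhibition), compound 1 `O=C1C=C(Nc2ccc(I)cc2)C(=O)c2c1nc1n2[C@H]2OC[C@@H](O)[C@H]2OC1` gives 2230 nM.
Compound 2 `O=C1C=C(Nc2ccccc2)C(=O)c2c1nc1n2[C@H]2OC[C@@H](O)[C@H]2OC1` gives > 4000 nM, which is a limit of this assay and not a number.
Compound 3 `O=C1C=C(Nc2ccc(Br)cc2)C(=O)c2c1nc1n2[C@H]2OC[C@@H](O)[C@H]2OC1` gives 2580 nM.

Compound 3 thus holds the highest of the two numbers in this assay, with compound 1 nearest, the gap being a 1.2-fold higher number from compound 1 to compound 3 (0.06 log units; within the scatter). Compound 2 sits at the limit of > 4000 nM in this assay, at which 1 of the 3 values shown sits.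

Compound 4 `O=C1C=C(N2CCCC2)C(=O)c2c1nc1n2[C@H]2OC[C@@H](O)[C@H]2OC1` differs from compound 3 by pyrrolidin-1-yl in place of (4-bromophenyl)amino on a double-bonded ring carbon.

The measured steps all concern the substituent on the aromatic ring of the (4-bromophenyl)amino group: an at least 1.7-fold higher number from compound 1 to compound 2 (0.25 log units; that floor lies within the scatter), an at least 1.5-fold lower number from compound 2 to compound 3 (0.19 log units; that floor lies within the scatter) and a 1.2-fold higher number from compound 1 to compound 3 (0.06 log units; within the scatter). Among the measured compounds shown here, none of them replaces that group itself, so no measured step bears directly on the change from compound 3 to compound 4. For the measured compounds named here, the only guide is that every measured compound carries an arylamino group and that all three numbers or limits lie in the same weak region of this assay.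

The account therefore expects compound 4 to land in that same region, with a wide range and a real chance that only a limit is reported. The step expected from compound 3 to compound 4 is a 1.9-fold higher number from compound 3 to compound 4 (0.29 log units; within the scatter). Compound 4 is estimated at 5000 nM, between 1500 nM and 20000 nM.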

Compound 4, half-maximal inhibitory concentration: > 16000 nM
Compound 4 gave a limit, no number; the forecaster's own chance of this, stated with the estimate: 55%; middle value at least 3.2-fold (0.50 log units) away from the limit.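

The earlier steps shown here in this assay changed only the substituent on the aromatic ring, whereas this change replaces the whole arylamino group on the double-bonded ring carbon, and here the steps pass beyond the scatter: an at least 6.2-fold higher number from compound 3 to compound 4 (0.79 log units; beyond the scatter) and an at least 7.1-fold higher number from compound 1 to compound 4 (0.85 log units; beyond the scatter). Compound 4 holds a limit of the assay and not a number, so these steps give only a floor for the size of the change: the limit of > 16000 nM in this assay, at which 1 of the 4 values shown sits. Compound 2 also holds a limit of the assay, and the step between compound 2 and compound 4 cannot be read: the limit of > 4000 nM in this assay, at which 1 of the 4 values shown sits.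

Pyrrolidin-1-yl differs from (4-bromophenyl)amino both in having no hydrogen-bond donor and in having no aromatic ring, and the compounds shown do not separate these two differences. Cyclohexylamino, which keeps the amine hydrogen without the aromatic ring, and methyl(phenyl)amino, which keeps the aromatic ring without that hydrogen, are groups that could tell which difference goes with the weaker read-out.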